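The source may hold more compounds than are shown below. What is called first, only, known or untested is meant among the compounds shown, and "the series" means these compounds.

In a functional assay on HCT-15 cells (Homo sapiens) for antiproliferative activity, read by sulforhodamine B assay (on this read-out higher numbers stand for weaker inhibition of growth and lower numbers for stronger inhibition of growth), compound 1 `CC(C)CCCOc1cccc(O)c1C(=O)/C=C/c1ccc(O)cc1` gives 11600 nM on the growth read-out, compound 2 `CC(C)(C)CCOc1cccc(O)c1C(=O)/C=C/c1ccc(C(=O)O)cc1` gives 2170 nM and compound 3 `O=C(/C=C/c1ccc(O)cc1)c1c(O)cccc1OCC1CCCC1` gives 3410 nM in the same test. Compound 3 cannot be told apart from compound 2, since their numbers lie within the usual scatter of each other, but it stands clearly lower than compound 1, which means stronger inhibition of growth.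

The next compound is compound 4 `O=C(/C=C/c1ccc(O)cc1)c1c(O)cccc1OCCC1CCCC1`, and the change from compound 3 is this: cyclopentylmethyl in place of cyclopentyl on a saturated chain carbon bound to an oxygen on an aromatic ring. In words, cyclopentylmethyl stands in place of cyclopentyl on a saturated chain carbon bound to an oxygen on an aromatic ring, which can also be read as cyclopentylmethoxy to 2-cyclopentylethoxy.

Within the data shown here, only one measured step touches this place: a 3.4-fold lower number from compound 1 to compound 3 (0.53 log units; beyond the scatter), with cyclopentyl in place of isopentyl. That step was modest but beyond the scatter. It is not the same change. Among the measured compounds shown here, compound 4 keeps the five-membered ring, and no measured pair shows this exact difference. A step no larger than that one is therefore expected, with no firm direction.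

The expected move is a 1.0-fold higher number from compound 3 to compound 4 (0.01 log units; within the scatter), which would stay within the scatter. For compound 4 the estimated value is 3500 nM, with an expected range from 1300 nM to 9000 nM in this assay.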

Compound 4, concentration for 50% growth inhibition: 3310 nM
The estimate for compound 4 lay 1.1-fold (0.02 log units) above the measured number; measured number inside the range.
By their numbers in this assay, from the lowest: compounds 2, 4 and 3 (each within the scatter of the next); then compound 1.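

In this assay, cyclopentylmethyl in place of cyclopentyl on a saturated chain carbon bound to an oxygen on an aromatic ring gives a 1.0-fold lower number from compound 3 to compound 4 (0.01 log units; within the scatter), so at this place a side group of 6 heavy atoms cannot be told apart from one of 5 when the five-membered ring is kept. Among these compounds, the open chain is a different matter: cyclopentyl in place of isobutyl on a saturated chain carbon, two bonds along the chain from an oxygen on an aromatic ring, gives a 3.5-fold lower number from compound 1 to compound 4 (0.54 log units; beyond the scatter), which now makes a second ring-bearing side chain that stands clearly apart from the isopentyl chain of the one open-chain compound that can be compared. Nothing measured here explains either result, neither the ring against the open chain nor the flat response to the added chain carbon.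

As far as these compounds go, whether this tolerance goes on with a longer chain between the oxygen and the ring, such as 3-cyclopentylpropyl, remains open. So does the effect of a cyclohexyl group at this place, or of an amine at the end of the chain.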